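A Sulfur Substituent Gives Way to an Azide

The source may report more compounds than this note shows. Statements on the series, on what has been measured and on what is new or still open speak of the compounds shown alone.

Compound 1, `OC[C@H]1OC(n2cnc3c(SCc4ccccc4)nccc32)[C@H](O)[C@@H]1O`, was tested in a functional assay (Homo sapiens) for inhibition of Nucleic Acid, tested at 100 uM; a lower number here means less inhibition, a higher number more inhibition at the concentration tested (going by the name of the read-out). For the measured compounds named here, at that concentration compound 1 gives 30%, the higher of the two numbers measured so far. Going by the values given here, the only other measured compound, compound 2 with the structure `c1ccc(Nc2[nH]ccc3ncnc2-3)cc1`, is built on a different arrangement of rings and carries no sugar. In this assay compound 2 gives 12%, a number lower than that of compound 1 by more than the usual scatter of such measurements. The two compounds differ in several places at once, so no single-point comparison exists between them.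

Compound 3, `[N-]=[N+]=Nc1nccc2c1ncn2C1O[C@H](CO)[C@@H](O)[C@H]1O`, keeps the sugar and the core of compound 1 but carries a different group on the core: azido in place of benzylsulfanyl on an aromatic carbon. The group that leaves, benzylsulfanyl, is large and contains a six-membered aromatic ring of carbon only; the group that enters, azido, is small and has no ring.

Among the compounds with values here, with no measured pair differing in one place, the size of this step is uncertain. The expectation is that a number 13 percentage points lower from compound 1 to compound 3 (beyond the scatter) goes in the direction of weaker inhibition, roughly at the edge of the scatter. Compound 3 is estimated at 17%, with a likely range from 0% to 38%.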

Compound 3, a percentage reported as inhibition, at one concentration (the size of the read-out at that concentration, not a potency): 4%
Beside the measured number, compound 3's estimate is 13 percentage points above it, within the range that was stated.
By their numbers in this assay, from the lowest: compounds 3 and 2 (each within the scatter of the next); then compound 1.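

In this assay, for the compounds shown here, the exchange on the aromatic carbon next to the ring nitrogen gives a number 26 percentage points lower from compound 1 to compound 3 (beyond the scatter), the first comparison here in which only one place differs. With the sugar and the core held the same, the group at this position clearly affects the read-out: benzylsulfanyl, the larger group with its six-membered aromatic ring of carbon only, goes with more inhibition at the concentration tested than azido, which is small and has no ring. No measurement shown here accounts for the size or direction of this step.

This single exchange alters the size of the group, the presence of a ring and the atom attached to the core all at once, so the compounds shown cannot tell which of these differences matters. From the compounds shown here alone, a methylsulfanyl group, which keeps the sulfur but has no ring, and a benzylamino group, which keeps the ring but puts nitrogen in place of the sulfur, would pull those features apart, and how either would behave at this position remains open.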